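This account rests on a few compounds, and the source may have more. Where it says the series, first, only, none or still open, it means among the compounds named here.

Two compounds share one core and differ only in the halogen on the benzoyl ring. Compound 1 `COc1cc(N(Cc2nc3ccccc3[nH]2)C(=O)c2ccc(F)cc2)cc(OC)c1OC` carries a fluorine and in a functional assay on PC-3 cells (Homo sapiens) for inhibition, read by MTT assay, with a stated time of 48 h (a lower number here means a stronger inhibitor, a higher number a weaker inhibitor), compound 1 gives 21900 nM. Compound 2 `COc1cc(N(Cc2nc3ccccc3[nH]2)C(=O)c2ccc(Br)cc2)cc(OC)c1OC` carries a bromine in the same spot, and in this assay compound 2 gives 19900 nM. Among the compounds with values here, the single step so far, a 1.1-fold lower number from compound 1 to compound 2 (0.04 log units; within the scatter), shows that swapping one halogen for another there left the number essentially unchanged; compound 2 therefore sits beside compound 1, not apart from it. Compound 3 `COc1cc(N(Cc2nc3ccccc3[nH]2)C(=O)c2cccc(Cl)c2)cc(OC)c1OC` brings a different kind of change, (3-chlorophenyl in place of 4-bromophenyl on a carbonyl carbon), moving the halogen to another ring position as well as changing its identity. Within the data shown here, no measured step covers a shift of position, so the expectation leans on the one halogen swap alone. Compound 3 is expected to give about 20000 nM, with a range from 7000 nM to 55000 nM, which means an expected step of a 1.0-fold higher number from compound 2 to compound 3 (0.00 log units; within the scatter).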

Compound 3, half-maximal inhibitory concentration: > 50000 nM
Compound 3: no number, only a limit; the forecaster's own chance of this, stated with the estimate: 10%; middle value at least 2.5-fold (0.39 log units) away from the limit.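

The ring on the carbonyl carbon does not tolerate every halogen change equally, which the swap from 4-fluorophenyl to 4-bromophenyl could not show. Replacing either ring with 3-chlorophenyl weakens the compound beyond the scatter, giving an at least 2.5-fold higher number from compound 2 to compound 3 (0.40 log units; beyond the scatter) and an at least 2.2-fold higher number from compound 1 to compound 3 (0.35 log units; beyond the scatter). In this assay, the result for compound 3 is a limit and not a number, so both steps are minimum sizes: the limit of > 50000 nM in this assay, at which 1 of the 3 values shown sits.

This one change alters both the identity of the halogen and where it sits on the ring, so the compounds shown do not separate the two effects. As far as these compounds go, how a ring carrying an amine or a carboxylic acid in place of a halogen would behave in this assay also remains open.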